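Methoxy on the amide of compound 2

The compounds below may be only part of what the source reports. "The series", "measured", "known", "first", "only" and "open" are said of these compounds alone.

In a functional assay on HCT-116 cells (Homo sapiens) for inhibition, read by luminescence and CellTiter-Glo, with a stated time of 72 h (a higher number here means a weaker inhibitor, a lower number a stronger inhibitor), compound 1 (`Cc1cc2c(C(=N)NO)cccc2n1-c1nc2c(c(NCc3cccc(O)c3)n1)CCC2`) gives 1100 nM and compound 2 (`Cc1cc2c(C(N)=O)cccc2n1-c1nc2c(c(NCc3cccc(O)c3)n1)CCC2`) gives 400 nM as the lower of the two numbers. Compound 3 (`CONC(=O)c1cccc2c1cc(C)n2-c1nc2c(c(NCc3cccc(O)c3)n1)CCC2`) carries methoxy in place of hydrogen on an amide-type nitrogen. For the measured compounds named here, the one measured step is a 2.8-fold lower number from compound 1 to compound 2 (0.44 log units; beyond the scatter) and it is modest, so it serves only as a rough guide to size. A similarly modest rise is expected in this assay (a 2.0-fold higher number from compound 2 to compound 3 (0.30 log units; within the scatter)) with no certainty about direction. Compound 3 is estimated at 800 nM within a range from 250 nM to 2500 nM until it is measured.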

Compound 3, half-maximal inhibitory concentration: 300 nM
The estimate for compound 3 lay 2.7-fold (0.43 log units) above the measured number, and the stated range covers the measured number.
By their numbers in this assay, from the lowest: compounds 3 and 2 (each within the scatter of the next); then compound 1.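

In this assay, the amide-type nitrogen of compound 2 accepts methoxy in place of hydrogen, with a 1.3-fold lower number from compound 2 to compound 3 (0.12 log units; within the scatter). The methoxycarbamoyl group of compound 3 also stands clear of the group in compound 1, with a 3.7-fold lower number from compound 1 to compound 3 (0.56 log units; beyond the scatter), so this position has room for some added atoms. No measurement shown gives a reason for these numbers. Still open, going by these compounds, is how a methyl or a longer ethoxy on this nitrogen would read. A carboxylic acid in place of the whole amide is equally untested among these compounds.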